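A few compounds are considered here, and "the series" means these few. Any claim that something is new, unique, unknown or untested is made for them only; others in the source may bear on it.

Measured so far:
- compound 1 `COc1cccc(-c2cc3[nH]nc(N)c3c(=O)[nH]2)c1` — 4%
- compound 2 `CC(=O)Nc1nn(C)c2cc(-c3ccccc3)[nH]c(=O)c12` — -9%
- compound 3 `CC(C)(C)c1cc2nn(-c3ccccc3)c(N)c2c(=O)[nH]1` — 7%

In an assay on isolated protein for inhibition of RAC-alpha serine/threonine-protein kinase (Homo sapiens), read by mobility shift assay, tested at 30 uM (on this read-out lower numbers stand for less inhibition and higher numbers for more inhibition at the one concentration tested (going by the name of the read-out)), all three numbers are small. Compound 3 holds the largest of them; compound 1 sits within the scatter of compound 3, so nothing separates the two, while compound 2 lies beyond the scatter, lower. Among the compounds with values here, no pair among the measured compounds differs in one place only, so no single structural step has a measured size here.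

Compound 4 `COc1ccc(-c2cc3nn(-c4ccccc4)c(N)c3c(=O)[nH]2)cc1` is not yet measured. It differs from compound 3 in one place: 4-methoxyphenyl in place of tert-butyl on an aromatic carbon. Within the data shown here, with no measured step of this kind, the expectation rests on the spread of the three numbers, which stays near the bottom of the scale. A step from compound 3 to compound 4 of a number 1 percentage points higher from compound 3 to compound 4 (within the scatter) is expected, that is, none beyond the scatter in either direction. For compound 4 the estimate in this assay is 8%, with a range from -8% to 25%.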

Compound 4, a percentage reported as inhibition, at one concentration (the size of the read-out at that concentration, not a potency): 16%
Beside the measured number, compound 4's estimate is 8 percentage points below it; the measured number falls inside the stated range.
By their numbers in this assay, from the lowest: compound 2; then compounds 1, 3 and 4 (each within the scatter of the next, the first and the last beyond it).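

In this assay, a number 9 percentage points higher from compound 3 to compound 4 (within the scatter) gives the first measured size for a change at this aromatic carbon next to the ring nitrogen. Replacing tert-butyl with 4-methoxyphenyl adds a six-membered aromatic ring and a hydrogen-bond acceptor at this position, yet the two compounds remain inseparable on this read-out, so neither addition can be credited with any effect. No available evidence bears on the size of this step.

From the compounds shown here alone, whether a different kind of group on this carbon, such as a primary amine, a carboxylic acid or a longer alkyl chain, would produce a step beyond the scatter remains open. With a single tested concentration and only low inhibition, the compounds shown give no potency for this series.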